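This account rests on a few compounds, and the source may have more. Where it says the series, first, only, none or still open, it means among the compounds named here.

Compound 2 `Cc1ccc(-c2nc(NO)c3cc(Cl)ccc3n2)cc1` is the hydroxyamino member of the series. For the measured compounds named here, in a functional assay on MCF7 cells (Homo sapiens) for antiproliferative activity, read by MTT assay, with a stated time of 48 h (on this read-out higher numbers stand for weaker inhibition and lower numbers for stronger inhibition), compound 2 gives 6.81 ug/mL, the second highest of the three numbers measured so far. Nearest to it is compound 3 `Cc1ccc(-c2nc3ccc(Cl)cc3c(=S)n2N)cc1`, which in this assay gives 9.25 ug/mL, a gap within the scatter of repeated measurements. Furthest is compound 1 `Cc1ccc(-c2nc3ccc(Cl)cc3c(=S)[nH]2)cc1`, which in this assay gives 3.35 ug/mL, a gap beyond the scatter.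

Compound 4 `Cc1ccc(-c2nc(SCC#N)c3cc(Cl)ccc3n2)cc1` differs from compound 2 by one change: (cyanomethyl)sulfanyl in place of hydroxyamino on an aromatic carbon.

Going by the values given here, the only single-point step measured so far is a 2.8-fold higher number from compound 1 to compound 3 (0.44 log units; beyond the scatter). That step concerns an aromatic nitrogen and leaves the aromatic carbon untouched, so it does not bear on the change to compound 4. Among the compounds with values here, no measured pair exchanges a group on that carbon; compound 2 is the only compound carrying hydroxyamino there, and none carries (cyanomethyl)sulfanyl. Within the data shown here, the series therefore gives no direct precedent, and the step to compound 4 is expected to fall within the scatter, in either direction, with a wide uncertainty.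

Compound 4 is estimated at 6 ug/mL in this assay, with a range from 2.5 ug/mL to 15 ug/mL. This estimate means an expected step of a 1.1-fold lower number from compound 2 to compound 4 (0.05 log units; within the scatter), essentially none beyond the scatter.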

Compound 4, half-maximal inhibitory concentration: 3.35 ug/mL
Estimate against measurement, compound 4: 1.8-fold (0.25 log units) above; the range from low to high includes it.
By their numbers in this assay, from the lowest: compounds 1 and 4 (each within the scatter of the next); then compounds 2 and 3 (each within the scatter of the next).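

For the compounds shown here, the step of a 2.0-fold lower number from compound 2 to compound 4 (0.31 log units; beyond the scatter) in this assay is the only reading on the aromatic carbon next to the ring nitrogen, and it shows that the number responds to a change of group at this place, modestly but beyond the scatter. The exchange removes hydroxyamino, with its 2 hydrogen-bond donors, and brings in (cyanomethyl)sulfanyl, with 0 hydrogen-bond donors and 4 heavy atoms, yet the number falls rather than rises, so in this pair the donors of hydroxyamino are not needed to hold the number in this assay. No measurement at hand bears on why the number moves with this change.

This single exchange alters the atom attached to the ring, the chain length and the nitrile at once, so the compounds shown do not separate what each contributes. Going by these compounds, whether the nitrile matters remains open, and methylsulfanyl at the same carbon would address that, while a simple amine there would test the attached atom and a longer cyanoalkyl chain would test the reach of the group.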